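This account rests on a few compounds, and the source may have more. Where it says the series, first, only, none or still open, it means among the compounds named here.

Measured so far:
- compound 1 `N#Cc1c(Cl)nc(SCc2nc3ccccc3[nH]2)nc1-c1ccccc1`: 3.28 nM
- compound 2 `N#Cc1c(Nc2ccccn2)nc(SCc2nc3ccccc3[nH]2)nc1-c1ccccc1`: 2.8 nM
- compound 3 `N#Cc1c(NC(N)=S)nc(SCc2nc3ccccc3[nH]2)nc1-c1ccccc1`: 3.37 nM

All three values come from a functional assay on NCI-H460 cells (Homo sapiens) for cytotoxicity, read by MTT assay, with a stated time of 3 days; on this read-out lower numbers stand for stronger inhibition and higher numbers for weaker inhibition. At 3.37 nM, compound 3 cannot be separated from the other two compounds, since its steps to both lie within the scatter: a 1.0-fold higher number from compound 1 to compound 3 (0.01 log units; within the scatter) and a 1.2-fold higher number from compound 2 to compound 3 (0.08 log units; within the scatter).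

Next is compound 4 `N#Cc1c(-c2ccccc2)nc(SCc2nc3ccccc3[nH]2)nc1N1CCNCC1`, with the change (a group of 6 heavy atoms (4 carbon, 2 nitrogen; one six-membered non-aromatic ring with 2 hetero atoms) in place of a group of 4 heavy atoms (1 carbon, 2 nitrogen, 1 sulfur; no ring), on an aromatic carbon). Piperazin-1-yl enters on an aromatic carbon of a six-membered aromatic ring with 2 nitrogen, ortho to a cyano group.

The measured steps bearing on this change all involve the same carbon. Besides the step above, there is a 1.2-fold lower number from compound 1 to compound 2 (0.07 log units; within the scatter), also within the scatter. Across compounds 1, 2 and 3, exchanging the group on this carbon has therefore produced no step beyond the scatter, and none of the three goes against this. None of them carries a non-aromatic ring there, however, so the range is kept wide. No shift beyond the scatter is expected in this assay, in either direction.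

The expected change is a 1.1-fold lower number from compound 3 to compound 4 (0.05 log units; within the scatter).

The estimate for compound 4 is 3 nM, with an expected range of 1 nM to 10 nM.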

Compound 4, half-maximal inhibitory concentration: 7.35 nM
For compound 4 the middle estimate is 2.5-fold (0.39 log units) below the measured one; measured number inside the range.
By their numbers in this assay, from the lowest: compounds 2, 1 and 3 (each within the scatter of the next); then compound 4.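

In this assay, among the compounds shown here, piperazin-1-yl is the first group on this aromatic carbon, the one ortho to a cyano group, to stand apart from the others: the change reads as a 2.2-fold higher number from compound 1 to compound 4 (0.35 log units; beyond the scatter) against chloro, a 2.6-fold higher number from compound 2 to compound 4 (0.42 log units; beyond the scatter) against (pyridin-2-yl)amino and a 2.2-fold higher number from compound 3 to compound 4 (0.34 log units; beyond the scatter) against the group of compound 3. The carbon is therefore not indifferent to what it carries: those three earlier groups stay within the scatter of each other, while the only non-aromatic ring among the four gives a higher number, which here means weaker inhibition. All three steps are modest, so this ring costs only a limited amount at this position, and compound 4 stays in the nanomolar range. Nothing available here bears on the origin of these steps.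

A morpholin-4-yl or piperidin-1-yl group on this carbon would show whether the higher number goes with the non-aromatic ring as such or with its second nitrogen. Also open, on these data alone, is whether an open-chain amine such as dimethylamino would sit with (pyridin-2-yl)amino or with piperazin-1-yl.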